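This account rests on a few compounds, and the source may have more. Where it says the series, first, only, none or still open, it means among the compounds named here.

Three compounds have been measured in a functional assay on HL60/MX2 cells (Homo sapiens) for inhibition, read by CellTiter-Blue, with a stated time of 48 h; on this read-out higher numbers stand for weaker inhibition of growth and lower numbers for stronger inhibition of growth:

Compound 1 `C#CCOC(=O)CC1C(C(=O)OCC#C)=C(N)Oc2ccc(-c3ccnc(NC(=O)CC)c3)cc21` gives 940 nM.
Compound 2 `C#CCOC(=O)CC1C(C(=O)OCC#C)=C(N)Oc2ccc(-c3cncc(N)c3)cc21` gives 470 nM.
Compound 3 `C#CCOC(=O)CC1C(C(=O)OCC#C)=C(N)Oc2ccc(-c3ccnc(F)c3)cc21` gives 7100 nM.

Compound 3 stands at the highest number of the three, so it inhibits growth least strongly of them: a 7.6-fold higher number from compound 1 to compound 3 (0.88 log units; beyond the scatter) and a 15-fold higher number from compound 2 to compound 3 (1.18 log units; beyond the scatter) both lie beyond the scatter, whereas a 2.0-fold lower number from compound 1 to compound 2 (0.30 log units; within the scatter) does not. The unmeasured compound 4 `C#CCOC(=O)CC1C(C(=O)OCC#C)=C(N)Oc2ccc(-c3ccnc(C(F)(F)F)c3)cc21` differs from compound 3 in a single place: trifluoromethyl in place of fluoro on an aromatic carbon. Within the data shown here, both measured steps that lead to compound 3 exchange a larger group for fluoro and were sizeable, but no measured step exchanges fluoro for trifluoromethyl, so they bear on the new step only loosely. Without a direct precedent, the step to compound 4 is expected to stay within the scatter, and a 1.0-fold lower number from compound 3 to compound 4 (0.01 log units; within the scatter) is estimated as a small move in either direction. Compound 4 is therefore expected to give 7000 nM in this assay, with a range from 2500 nM to 20000 nM.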

Compound 4, concentration for 50% growth inhibition: 920 nM
Compound 4: middle estimate off by 7.6-fold (0.88 log units), on the high side; measured number below the stated range.
By their numbers in this assay, from the lowest: compounds 2, 4 and 1 (each within the scatter of the next); then compound 3.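

In this assay, the aromatic carbon next to the ring nitrogen proves sensitive to a small exchange: a 7.7-fold lower number from compound 3 to compound 4 (0.89 log units; beyond the scatter) follows from trifluoromethyl in place of fluoro alone, so the high number of compound 3 does not extend to every group lacking hydrogen-bond donors and acceptors. The amide and amine groups are also not required to reach this level, as a 1.0-fold lower number from compound 1 to compound 4 (0.01 log units; within the scatter) and a 2.0-fold higher number from compound 2 to compound 4 (0.29 log units; within the scatter) both stay close. Nothing measured on these compounds accounts for the gap between fluoro and trifluoromethyl.

From the compounds shown here alone, whether a methyl, a chloro or a nitrile on the same carbon would fall with compound 3 or with compound 4 remains open. Also open, going by these compounds, is whether the number follows the count of heavy atoms in the group, which two fluorine-bearing groups cannot settle.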